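The source may report more compounds than this note shows. Statements on the series, on what has been measured and on what is new or still open speak of the compounds shown alone.

Among the compounds with values here, compound 2 `CN1CCN(c2ccc(C3=NN(S(=O)(=O)c4ccc(C#N)cc4)C(c4ccc(N(C)C)cc4)C3)cc2)CC1` stands highest of the two numbers measured so far: in a functional assay on HCC1806 cells (Homo sapiens) for inhibition, read by sulforhodamine B assay, tested at 10 uM (on this read-out lower numbers stand for less inhibition and higher numbers for more inhibition at the one concentration tested (going by the name of the read-out)), compound 2 gives 99.8%, while compound 1 `CN1CCN(c2ccc(C3=NNC(c4ccc(N(C)C)cc4)C3)cc2)CC1` gives 31.2%. Within the data shown here, the one step measured, a number 68.6 percentage points higher from compound 1 to compound 2 (beyond the scatter), concerns a different place in the shared core, namely (4-cyanophenyl)sulfonyl in place of hydrogen on an amine nitrogen in a ring. Compound 3 `CN(C)c1ccc(C2CC(c3ccc(-n4cncn4)cc3)=NN2S(=O)(=O)c2ccc(C#N)cc2)cc1` keeps that (4-cyanophenyl)sulfonyl group and differs from compound 2 in one place: 1H-1,2,4-triazol-1-yl in place of 4-methylpiperazin-1-yl on an aromatic carbon. Among the measured compounds shown here, no measured step bears on this exchange of 4-methylpiperazin-1-yl for 1H-1,2,4-triazol-1-yl, so its effect cannot be read from the numbers in hand. Because compound 2 already sits near the top of the scale at 99.8%, the expected step of a number 14.8 percentage points lower from compound 2 to compound 3 (beyond the scatter) is a modest downward one, carrying wide uncertainty. Compound 3 is estimated at 85%, expected to fall between 50% and 100%.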

Compound 3, a percentage reported as inhibition, at one concentration (the size of the read-out at that concentration, not a potency): 33.1%
Beside the measured number, compound 3's estimate is 51.9 percentage points above it; measured number below the stated range.
By their numbers in this assay, from the lowest: compounds 1 and 3 (each within the scatter of the next); then compound 2.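

The earlier step showed what adding the (4-cyanophenyl)sulfonyl group does; this one shows that, in this assay, the group on the aromatic carbon para to a large group also counts, with a number 66.7 percentage points lower from compound 2 to compound 3 (beyond the scatter) when 1H-1,2,4-triazol-1-yl replaces 4-methylpiperazin-1-yl. The (4-cyanophenyl)sulfonyl group is present in both compounds, so it does not secure a high number by itself. Nothing available explains the drop.

The exchange alters ring size, aromatic character and hetero atom count all at once, so the compounds shown leave open which of these differences matters. A morpholin-4-yl group at the same place, which keeps a six-membered non-aromatic ring but has oxygen in place of the methyl-bearing nitrogen, would help to separate these differences.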